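Anilide cap in place of the thiazolyl cap

The source may hold more compounds than are shown below. What is called first, only, known or untested is meant among the compounds shown, and "the series" means these compounds.

Measured compounds and values in a functional assay on HCT-116 cells (Homo sapiens) for inhibition, read by colorimetric assay, with a stated time of 3 days; on this read-out higher numbers stand for weaker inhibition and lower numbers for stronger inhibition:
compound 1, `O=C(CCCCCCNC(=O)C(O)(O)C(F)(F)F)Nc1nccs1`, 10800 nM
compound 2, `O=C(CCCCCCNC(=O)C(O)(O)C(F)(F)F)Nc1nc(-c2ccccc2)c(-c2ccccc2)s1`, 29900 nM
compound 3, `O=C(CCCCCCNC(=O)C(O)(O)C(F)(F)F)Nc1ncc(-c2ccccc2)s1`, 2660 nM

Compound 1 gives the second highest of the three numbers in this assay; compound 2 stands above it and compound 3 below it, both steps beyond the scatter. The measured steps all concern substitution on the ring of the shared cap: a 4.1-fold lower number from compound 1 to compound 3 (0.61 log units; beyond the scatter) and an 11-fold lower number from compound 2 to compound 3 (1.05 log units; beyond the scatter). Among the compounds with values here, neither step exchanges the ring itself, so no measured step bears directly on the change to compound 4.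

Compound 4, `COc1ccc(NC(=O)CCCCCCNC(=O)C(O)(O)C(F)(F)F)cc1`, differs from compound 1 as follows: 4-methoxyphenyl in place of 1,3-thiazol-2-yl on an amide-type nitrogen. Within the data shown here, the cap is exchanged for a ring not represented among the measured compounds, and the data give no step of this kind to lean on. The expectation is therefore no step beyond the scatter, with a wide range around the value of compound 1. Compound 4 is expected to give 9000 nM in this assay, within 2500 nM to 32000 nM, which corresponds to an expected step of a 1.2-fold lower number from compound 1 to compound 4 (0.08 log units; within the scatter).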

Compound 4, half-maximal inhibitory concentration: 4520 nM
Compound 4: the middle estimate sits 2.0-fold (0.30 log units) above what was measured; measured number inside the range.
By their numbers in this assay, from the lowest: compounds 3 and 4 (each within the scatter of the next); then compound 1; then compound 2.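

In this assay, within the data shown here, the step of a 2.4-fold lower number from compound 1 to compound 4 (0.38 log units; beyond the scatter) is the first measured exchange of the ring itself on the amide-type nitrogen, whereas the earlier steps only changed substitution on the 1,3-thiazol-2-yl ring. It shows that this position tolerates the loss of the 1,3-thiazol-2-yl group: a six-membered aromatic ring of carbon only, carrying a methoxy group, gives a lower number, so inhibition in these cells does not depend on keeping the 1,3-thiazol-2-yl cap. Among these compounds, nothing in hand explains why this exchange lowers the number, and the single step cannot be divided between the change of ring and the added methoxy group.

A plain phenyl cap would show how much of the step belongs to the ring and how much to the methoxy group, and an amine or a carboxylic acid in place of the methoxy group would test how far this substituent can vary. As far as these compounds go, whether the anilide cap keeps its standing with a shorter or longer chain also remains open.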